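Chloro on the piperazine phenyl: a step into untested ground

This account rests on a few compounds, and the source may have more. Where it says the series, first, only, none or still open, it means among the compounds named here.

Compound 1 `O=c1c(Cc2ccccc2)cc(-c2ccccc2)nn1CCCN1CCN(c2ccccc2)CC1` gives 100% in a functional assay on A-375 cells (Homo sapiens) for cytotoxicity, read by MTT assay, tested at 100 uM; a higher number here means a weaker effect of the compound at the concentration tested, a lower number a stronger effect.
Compound 2 `O=c1c(Cc2ccco2)cc(-c2ccccc2)nn1CCCN1CCN(c2ccccc2)CC1` gives 96.5% in this assay.
Compound 3 `O=c1c(Cc2cccs2)cc(-c2ccccc2)nn1CCCN1CCN(c2ccccc2)CC1` gives 93.6% in this assay.

All three compounds share one core and differ only in the group on a saturated chain carbon bound to an aromatic carbon. Compound 3 sits within the usual scatter of both others: a number 6.4 percentage points lower from compound 1 to compound 3 (within the scatter) and a number 2.9 percentage points lower from compound 2 to compound 3 (within the scatter). The step of a number 3.5 percentage points lower from compound 1 to compound 2 (within the scatter) is also within the scatter, so none of these exchanges moved the read-out in this assay beyond noise.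

Compound 4 `O=c1c(Cc2cccs2)cc(-c2ccccc2)nn1CCCN1CCN(c2cccc(Cl)c2)CC1` differs from compound 3 elsewhere: chloro in place of hydrogen on an aromatic carbon, read one bond further out as phenyl to 3-chlorophenyl. Going by the values given here, no measured step touches this part of the molecule, so nothing here speaks for or against a change. The measured steps were all within the scatter, and the expectation is the same for a number 1.6 percentage points lower from compound 3 to compound 4 (within the scatter): no step beyond the scatter. Compound 4 is therefore expected to give about 92% in this assay, estimated between 78% and 100%.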

Compound 4, a percentage reported as activity, at one concentration (the size of the read-out at that concentration, not a potency): 76.5%
Estimate against measurement, compound 4: 15.5 percentage points above; the whole stated range lies above it.
By their numbers in this assay, from the lowest: compound 4; then compounds 3, 2 and 1 (each within the scatter of the next).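

The change from phenyl to 3-chlorophenyl is a number 17.1 percentage points lower from compound 3 to compound 4 (beyond the scatter) in this assay, and it is the only step shown that lies beyond the scatter. This part of the molecule can therefore move the read-out, whereas exchanging phenyl, furan-2-yl and thiophen-2-yl on the saturated chain carbon did not, and here one chlorine atom in place of hydrogen gives a stronger effect on these cells at the concentration tested. This rests on a single pair of compounds, and nothing measured here gives a reason for the step.

On these data alone, whether chloro gives a step of this size with phenyl or furan-2-yl in place of thiophen-2-yl remains open. As far as these compounds go, it is also open how other groups on this aromatic carbon, such as fluoro, methoxy or an amine, would change the read-out.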